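The compounds below may be only part of what the source reports. "The series", "measured", "known", "first", "only" and "open" are said of these compounds alone.

Three compounds sharing one core were tested in a functional assay on CaEs17 cells (Homo sapiens) for cytotoxicity, read by MTT assay, with a stated time of 72 h; on this read-out higher numbers stand for weaker inhibition and lower numbers for stronger inhibition: compound 1 `C=C1C(=O)[C@@]23C(=O)OC[C@]4(C(=O)CCC(C)(C)[C@H]4C=O)[C@@H]2CC[C@@H]1[C@H]3OC(=O)CC` gives 1400 nM, compound 2 `C=C1C(=O)[C@@]23C(=O)OC[C@]4(C(=O)CCC(C)(C)[C@H]4C=O)[C@@H]2CC[C@@H]1[C@H]3OC(=O)c1ccc(C)cc1` gives 1050 nM, and compound 3 `C=C1C(=O)[C@@]23C(=O)OC[C@]4(C(=O)CCC(C)(C)[C@H]4C=O)[C@@H]2CC[C@@H]1[C@H]3OC(=O)c1ccc([N+](=O)[O-])cc1` gives 2680 nM. Compound 3 stands level with compound 1, as a 1.9-fold higher number from compound 1 to compound 3 (0.28 log units; within the scatter) shows, and clear only of compound 2, with a 2.6-fold higher number from compound 2 to compound 3 (0.41 log units; beyond the scatter). The remaining measured step is a 1.3-fold lower number from compound 1 to compound 2 (0.12 log units; within the scatter). Compound 4 `C=C1C(=O)[C@@]23C(=O)OC[C@]4(C(=O)CCC(C)(C)[C@H]4C=O)[C@@H]2CC[C@@H]1[C@H]3OC(=O)c1ccc(F)cc1` keeps the core of compound 3 and changes one group: fluoro in place of nitro on an aromatic carbon. Compound 3 alone separates from compound 2, and only modestly, so removing the nitro is expected to shift the number slightly, towards the other two values. The expected step is a 1.8-fold lower number from compound 3 to compound 4 (0.27 log units; within the scatter), a small one. For compound 4 the estimated value in this assay is 1450 nM, with an expected range from 700 nM to 2900 nM.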

Compound 4, half-maximal inhibitory concentration: 8310 nM
The estimate for compound 4 lay 5.7-fold (0.76 log units) below the measured number; the whole stated range lies below it.
By their numbers in this assay, from the lowest: compounds 2, 1 and 3 (each within the scatter of the next, the first and the last beyond it); then compound 4.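

In this assay the fluoro group, para to a large group on the aromatic ring, takes the number clear of all three earlier compounds (a 3.1-fold higher number from compound 3 to compound 4 (0.49 log units; beyond the scatter); a 7.9-fold higher number from compound 2 to compound 4 (0.90 log units; beyond the scatter); a 5.9-fold higher number from compound 1 to compound 4 (0.77 log units; beyond the scatter)). This position therefore tolerates less than the narrow spread among the ethyl, 4-methylphenyl and 4-nitrophenyl compounds suggested, since one exchange on the ring moves the number beyond the scatter towards weaker inhibition. Nothing available accounts for this shift. As far as these compounds go, whether a chloro or a methoxy group here would follow fluoro or stay with nitro and methyl remains open.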